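The compounds below may be only part of what the source reports. "The series", "measured", "known", "first", "only" and "open" are said of these compounds alone.

Measured compounds in an assay on CHO cells for displacement of a labelled ligand from C-X-C chemokine receptor type 4 (Homo sapiens), with a stated time of 40 min; on this read-out higher numbers stand for weaker inhibition and lower numbers for stronger inhibition:
- compound 1 `c1cc(CNCCCNC2CCCCC2)cc(CNCCCNC2CCCCC2)c1`: 156 nM
- compound 2 `O=[N+]([O-])c1cc(CNCCCNC2CCCCC2)cc(CNCCCNC2CCCCC2)c1`: 147 nM

Compound 2 stands alongside compound 1 rather than apart from it: the step of a 1.1-fold lower number from compound 1 to compound 2 (0.03 log units; within the scatter) is within the scatter, so the two numbers are to be read as the same result for the purpose of this series.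

Compound 3 `Nc1cc(CNCCCNC2CCCCC2)cc(CNCCCNC2CCCCC2)c1` has not been measured. It differs from compound 2 by amino in place of nitro on an aromatic carbon. For the measured compounds named here, the only measured step that bears on this position is the one from hydrogen to nitro at the same aromatic carbon, a 1.1-fold lower number from compound 1 to compound 2 (0.03 log units; within the scatter), which left the number unchanged beyond the scatter. Nothing in the two measured compounds points to a substituent at this carbon moving the number in either direction, so a step no larger than the scatter is expected in this assay for the move to amino as well; the estimate is a 1.0-fold higher number from compound 2 to compound 3 (0.01 log units; within the scatter). On that basis compound 3 is expected to give 150 nM in this assay, with a range of 60 nM to 400 nM.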

Compound 3, half-maximal inhibitory concentration: 81.2 nM
The estimate for compound 3 lay 1.8-fold (0.27 log units) above the measured number, within the range that was stated.
By their numbers in this assay, from the lowest: compounds 3, 2 and 1 (each within the scatter of the next).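

Notes on the aromatic carbon: in this assay, the swap of nitro for amino gives a 1.8-fold lower number from compound 2 to compound 3 (0.26 log units; within the scatter), even though this change replaces 3 heavy atoms with 1 heavy atom and brings in 1 hydrogen-bond donor where nitro has 0 hydrogen-bond donors. Amino in place of hydrogen at the same carbon gives a 1.9-fold lower number from compound 1 to compound 3 (0.28 log units; within the scatter), so hydrogen, nitro and amino now all read as one result and this carbon has so far accepted three quite different occupants without a step beyond the scatter. No measurement on these compounds offers an explanation for the numbers at this position.

From the compounds shown here alone, it remains open whether a carboxylic acid, a methyl group or an acetamide on this carbon would also stay within the scatter, or whether some group here would produce a real step in either direction. The compounds shown also leave open whether the cyclohexyl groups or the three-carbon chains in the shared core tolerate change in the same way as this aromatic carbon.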